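The source may hold more compounds than are shown below. What is called first, only, known or untested is meant among the compounds shown, and "the series" means these compounds.

Compound 1 `Cc1cc(C)c(NC(=O)N(Cc2ccc(-c3n[nH]c(C)n3)cc2)C2CCCCCC2)c(C)c1` was tested in a functional assay on a cell-free system (plasma) with sterol O-acyltransferase, Soat (Rattus norvegicus) as the target; a lower number here means that less compound is needed, a higher number that more compound is needed for the effect. In this assay compound 1 gave only a limit, > 1 mg/kg, rather than an exact number. Compound 2 `CSc1cc(C)nc(SC)c1NC(=O)N(Cc1ccccc1)Cc1ccc(-c2cnn(C)c2)cc1` also gave only a limit in this assay, namely > 0.1 mg/kg. Both results are boundaries of the measurement, as the two lines the limit of > 0.1 mg/kg in this assay, at which 1 of the 2 values shown sits, and the limit of > 1 mg/kg in this assay, at which 1 of the 2 values shown sits, show, so compound 1 cannot be ranked against compound 2 on these numbers. Compound 3 `Cc1cc(C)c(NC(=O)N(Cc2ccc(-c3ccsc3)cc2)C2CCCCCC2)c(C)c1` has not yet been measured. It differs from compound 1 by a single change, (thiophen-3-yl in place of 5-methyl-1H-1,2,4-triazol-3-yl on an aromatic carbon), that is, thiophen-3-yl in place of 5-methyl-1H-1,2,4-triazol-3-yl on an aromatic carbon. Among the measured compounds shown here, no measured pair shows how such a swap shifts the dose, so the step of a number no higher from compound 1 to compound 3 (the limit leaves the size open) is expected to stay within the usual scatter, with no clear direction. Compound 3 is therefore expected to need about 1 mg/kg, somewhere between 0.3 mg/kg and 3 mg/kg, and may again be reported only as a limit.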

Compound 3, dose for half-maximal effect: 0.51 mg/kg
For compound 3 the middle estimate is 2.0-fold (0.29 log units) above the measured one; the range from low to high includes it.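

Swapping 5-methyl-1H-1,2,4-triazol-3-yl for thiophen-3-yl on this aromatic carbon, para to a large group, gives in this assay an at least 1.9-fold lower number from compound 1 to compound 3 (0.29 log units; that floor lies within the scatter). Compound 3 thus provides the first exact number among the compounds shown, and it shows that this place can carry a five-membered aromatic ring with 0 hydrogen-bond donors and still give a measurable dose. Compound 1 gave only a limit, so the step has a floor but no known size: the limit of > 1 mg/kg in this assay, at which 1 of the 3 values shown sits.

The swap changes the ring atoms and the hydrogen-bond donors together, and the compounds shown cannot separate these two changes. They also leave open how a carboxylic acid, an amine or a plain phenyl ring at this place would compare with thiophen-3-yl.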